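The source may report more compounds than this note shows. Statements on the series, on what has been measured and on what is new or still open speak of the compounds shown alone.

Compound 1 `CC(C)(C)c1ccc(C(=O)N2CCC3(CC2)C(=O)N(CC(=O)NCCN)CN3c2ccccc2)cc1` gives 7000 nM in an assay on HEK293 cells for displacement of a labelled ligand from NPC1-like intracellular cholesterol transporter 1 (Homo sapiens); on this read-out higher numbers stand for weaker inhibition and lower numbers for stronger inhibition. Compound 2 `CC(C)(C)c1ccc(C(=O)N2CCC3(CC2)C(=O)N(CC(=O)NCCCCO)CN3c2ccccc2)cc1` gives 19200 nM in this assay, the change between the two being a 2.7-fold higher number from compound 1 to compound 2 (0.44 log units; beyond the scatter). Among the measured compounds shown here, on the two numbers so far compound 2 carries the highest value, its only neighbour being compound 1 at the lower number just stated.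

Compound 3 `CC(C)(C)OC(=O)NCCCNC(=O)CN1CN(c2ccccc2)C2(CCN(C(=O)c3ccc(C(C)(C)C)cc3)CC2)C1=O` differs from compound 2 by (tert-butoxycarbonyl)amino in place of hydroxymethyl on a saturated chain carbon, three bonds along the chain from an amide-type nitrogen. For the measured compounds named here, the single measured step swaps amino for 2-hydroxyethyl, which is not the present change, so it bears on it only loosely; it shows that alterations at the chain end move this assay by a modest amount. Going by the values given here, no step with a (tert-butoxycarbonyl)amino group exists. The expectation for compound 3 is therefore a number close to that of compound 2, with the step of a 1.0-fold higher number from compound 2 to compound 3 (0.02 log units; within the scatter) expected to stay near the scatter. The estimate for compound 3 in this assay is 20000 nM, with a range from 6000 nM to 60000 nM.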

Compound 3, half-maximal inhibitory concentration: 4500 nM
The estimate for compound 3 lay 4.4-fold (0.65 log units) above the measured number; the measured number lies below the stated range.
By their numbers in this assay, from the lowest: compounds 3 and 1 (each within the scatter of the next); then compound 2.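

In this assay, the chain end accepts a group with more heavy atoms without loss: (tert-butoxycarbonyl)amino in place of hydroxymethyl gives the step (a 4.3-fold lower number from compound 2 to compound 3 (0.63 log units; beyond the scatter)), so the hydroxyl-ended chain of compound 2 is the outlier so far. The comparison with the amino end of compound 1 (a 1.6-fold lower number from compound 1 to compound 3 (0.19 log units; within the scatter)) stays within the scatter, so a free amino end and the longer chain capped with (tert-butoxycarbonyl)amino are not told apart here. Nothing available bears on why the number moves at this position.

As far as these compounds go, it remains open whether the hydroxyl end itself or the chain carrying it sets the higher number of compound 2, which a free amine on the 3-carbon propyl chain or a carboxylic acid at the same end would help to separate. From the compounds shown here alone, whether a different group here, such as a benzyl carbamate or a simple acetamide, can move the number well beyond the level of compounds 1 and 3 is also open.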